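The source may hold more compounds than are shown below. What is called first, only, known or untested is meant among the compounds shown, and "the series" means these compounds.

In an ADME assay on microsomes from liver (Homo sapiens) for metabolic stability (a lower number here means that the compound disappears faster, a higher number that the compound lasts longer), compound 2 `CC(C)C(c1noc(=O)[nH]1)c1ccc(-c2ccc3cccc(F)c3c2)[nH]c1=O` gives > 3 h, which is a limit of the assay and not a number. Compound 1 `CC(C)C(c1ncc[nH]1)c1ccc(-c2ccc3cccc(F)c3c2)[nH]c1=O` gives < 0.0667 h, also a limit. Compound 3 `Cc1c[nH]c(C(c2ccc(-c3ccc4cccc(F)c4c3)[nH]c2=O)C(C)C)n1` differs from compound 2 by a group of 6 heavy atoms (4 carbon, 2 nitrogen; one five-membered aromatic ring with 2 hetero atoms) in place of a group of 6 heavy atoms (2 carbon, 2 nitrogen, 2 oxygen; one five-membered aromatic ring with 3 hetero atoms), on a saturated chain carbon bound to an aromatic carbon and a saturated chain carbon, so 4-methyl-1H-imidazol-2-yl enters on the saturated chain carbon. Within the data shown here, its five-membered aromatic ring with 2 hetero atoms matches the ring type in compound 1, so the one measured step bears directly: an at least 44-fold higher number from compound 1 to compound 2 (1.65 log units; beyond the scatter). A large fall in this assay is therefore expected, roughly reversing that step. The expected change is an at least 42-fold lower number from compound 2 to compound 3 (1.63 log units; beyond the scatter). For compound 3 the estimated half-life is 0.07 h, with an expected range of 0.03 h to 0.3 h.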

Compound 3, half-life: 0.09 h
For compound 3 the middle estimate is 1.3-fold (0.11 log units) below the measured one, and the stated range covers the measured number.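

In this assay, 4-methyl-1H-imidazol-2-yl on this saturated chain carbon, in place of the ring of compound 2, brings an at least 33-fold lower number from compound 2 to compound 3 (1.52 log units; beyond the scatter). Methyl in place of hydrogen on an aromatic carbon brings an at least 1.3-fold higher number from compound 1 to compound 3 (0.13 log units; that floor lies within the scatter), so the added methyl does not close the gap to compound 2. The true size of that small step stays unknown, as compound 1 stands at a limit: the limit of < 0.0667 h in this assay, at which 1 of the 3 values shown sits.

The compounds shown leave open how an amine or a carboxylic acid on this saturated chain carbon would fare in this assay.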